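This account rests on a few compounds, and the source may have more. Where it says the series, first, only, none or still open, it means among the compounds named here.

Measured so far:
compound 1 `COC(OC)[C@]1(C)Oc2ccc(N)cc2[C@@H](/N=C(\NC#N)NCc2ccccc2)[C@@H]1O` — in a functional assay (neuronal) with Rattus norvegicus as the target, read by LDH release, tested at 30 uM (a higher number here means a weaker inhibitor, a lower number a stronger inhibitor), compound 1 gives 8000 nM
compound 2 `COC(OC)[C@@]1(C)Oc2ccc(N)cc2[C@H](/N=C(\NC#N)NCc2ccccc2)[C@H]1O` — in this assay compound 2 gives 9200 nM

The two numbers are separated only by a 1.2-fold higher number from compound 1 to compound 2 (0.06 log units; within the scatter), which lies within the scatter, so compound 2 stands level with compound 1 and neither can be called the stronger inhibitor. Compound 3 `COC(OC)[C@]1(C)Oc2ccc(N)cc2[C@H](/N=C(\NC#N)NCc2ccccc2)[C@@H]1O` has not yet been measured. It differs from compound 2 as follows: the two compounds have the same atoms and bonds and differ only in configuration as drawn: 2 of 4 stereo elements differ; a stereocentre at a saturated ring carbon is drawn S in compound 2 and R in compound 3; a stereocentre at a saturated ring carbon is drawn R in compound 2 and S in compound 3. Within the data shown here, the only measured step that bears on a change of configuration alone is the one from compound 1 to compound 2, a 1.2-fold higher number from compound 1 to compound 2 (0.06 log units; within the scatter), where the configuration changed at more stereocentres than it does here and the number hardly moved. A step beyond the scatter is therefore not expected; the estimated step is a 1.0-fold lower number from compound 2 to compound 3 (0.01 log units; within the scatter). Compound 3 is expected to give about 9000 nM in this assay, with a likely range from 4000 nM to 25000 nM.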

Compound 3, half-maximal inhibitory concentration: 2200 nM
Compound 3: middle estimate off by 4.1-fold (0.61 log units), on the high side; the whole stated range lies above it.
By their numbers in this assay, from the lowest: compound 3; then compounds 1 and 2 (each within the scatter of the next).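

Configuration alone can matter at these ring carbons: in this assay, changing a single saturated ring carbon gives a 3.6-fold lower number from compound 1 to compound 3 (0.56 log units; beyond the scatter), and changing two gives a 4.2-fold lower number from compound 2 to compound 3 (0.62 log units; beyond the scatter). The earlier pair, with three stereocentres changed, showed only a 1.2-fold higher number from compound 1 to compound 2 (0.06 log units; within the scatter), so among these compounds the size of the step does not follow the count of changed centres, and that pair goes against any such rule. The single-centre step can be put down to the arrangement in space at that carbon, because nothing else changes: the fact that compounds 1 and 3 differ only in the configuration as drawn

The step with two changed ring carbons cannot say which of them carries the difference. Also open, as far as these compounds go, is whether the arrangement of compound 3 keeps its lower number when the benzyl group gives way to a longer chain such as phenethyl, or the amine to a carboxylic acid.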